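The compounds below may be only part of what the source reports. "The series", "measured", "known", "first", "only" and "open" are said of these compounds alone.

Compound 1 `C[C@H](NC(=O)c1c(-c2ccccc2)nnn1Cc1ccc(F)cc1)c1ccc(C(=O)O)cc1`: 330 nM
Compound 2 `COc1cccc(Cn2nnc(-c3ccccc3)c2C(=O)N[C@@H](C)c2ccc(C(=O)O)cc2)c1`: 96.8 nM

In a functional assay on CHO cells for antagonist activity at prostaglandin E2 receptor EP4 subtype (Homo sapiens), read by calcium flux, with a stated time of 15 min (on this read-out higher numbers stand for weaker inhibition and lower numbers for stronger inhibition), compound 2 gives 96.8 nM and holds the lowest number of the two measured; compound 1 gives 330 nM, and the step of a 3.4-fold lower number from compound 1 to compound 2 (0.53 log units; beyond the scatter) lies beyond the scatter. Compound 3 `C[C@H](NC(=O)c1c(-c2ccccc2)nnn1CC1CCCCC1)c1ccc(C(=O)O)cc1` has not yet been measured. It differs from compound 2 in one place: cyclohexyl in place of 3-methoxyphenyl on a saturated chain carbon bound to an aromatic nitrogen. Among the compounds with values here, only one measured step touches the group on the saturated chain carbon bound to the aromatic nitrogen, a 3.4-fold lower number from compound 1 to compound 2 (0.53 log units; beyond the scatter), and that step swaps one aromatic ring for another; no measured pair shows what a non-aromatic ring does at this position. The direction of the step to compound 3 is therefore open, and a wide range is appropriate. Compound 3 is expected to land near 200 nM in this assay, with a range of 60 nM to 700 nM, which corresponds to an expected step of a 2.1-fold higher number from compound 2 to compound 3 (0.32 log units; beyond the scatter).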

Compound 3, half-maximal inhibitory concentration: > 10000 nM
Compound 3 ended at the assay's limit (the forecaster's own chance of this, stated with the estimate: 5%); at least 50-fold (1.69 log units) between middle value and limit.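

In this assay, the group on a saturated chain carbon bound to an aromatic nitrogen proved far more sensitive to the kind of ring it carries than the earlier pair could show. That pair, with its two aromatic rings, gave only a 3.4-fold lower number from compound 1 to compound 2 (0.53 log units; beyond the scatter), whereas cyclohexyl gives an at least 100-fold higher number from compound 2 to compound 3 (2.01 log units; beyond the scatter) and an at least 30-fold higher number from compound 1 to compound 3 (1.48 log units; beyond the scatter). The value of compound 3 is a limit of the assay and not a number, so the full size of both steps stays unknown: the limit of > 10000 nM in this assay, at which 1 of the 3 values shown sits.

As far as these compounds go, with a single non-aromatic ring among the three compounds, it remains open whether any non-aromatic group can give a measurable value at this position. From the compounds shown here alone, it is also open whether a pyridyl ring, a tetrahydropyranyl ring or a longer chain ending in cyclohexyl would behave like cyclohexyl or like the two aromatic rings.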